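Thiophene in place of nitrophenyl on the enone chain

The source may report more compounds than this note shows. Statements on the series, on what has been measured and on what is new or still open speak of the compounds shown alone.

Working notes on three measured enones and a fourth awaiting a number. In a functional assay on DU-145 cells (Homo sapiens) for inhibition, read by trypan blue exclusion, with a stated time of 96 h (a higher number here means a weaker inhibitor of growth, a lower number a stronger inhibitor of growth), compound 1 `Cc1ccsc1/C=C(/SCc1ccc(Cl)c(Cl)c1)C(=O)c1ccc(Cl)cc1` gives 50000 nM, compound 2 `Cc1ccc(CS/C(=C/c2ccc(Br)cc2)C(=O)c2ccc(Cl)cc2)cc1` gives 10000 nM, and compound 3 `Cc1ccc(CS/C(=C/c2cc([N+](=O)[O-])ccc2F)C(=O)c2ccc(Cl)cc2)cc1` gives 1000 nM. Among the compounds with values here, compound 3 holds the lowest number of the three: the nearest is compound 2, and the single step that compares them is a 10-fold lower number from compound 2 to compound 3 (1.00 log units; beyond the scatter); compound 1 lies furthest away.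

Compound 4 `Cc1ccc(CS/C(=C/c2sccc2C)C(=O)c2ccc(Cl)cc2)cc1` is the next member. The change from compound 3 is 3-methylthiophen-2-yl in place of 2-fluoro-5-nitrophenyl on a double-bonded chain carbon bound to a double-bonded chain carbon. Within the data shown here, the only measured step at this position, a 10-fold lower number from compound 2 to compound 3 (1.00 log units; beyond the scatter), shows that the group on the double-bonded chain carbon moves this assay strongly, and the nitro-bearing ring gave the lowest number. Compound 1 already carries 3-methylthiophen-2-yl at the same place, though with a different benzyl on sulfur, and its number in this assay is the highest of the set. A rise is therefore expected rather than a fall.

The step is estimated as a 25-fold higher number from compound 3 to compound 4 (1.40 log units; beyond the scatter). In this assay compound 4 is expected near 25000 nM, within a range of 8000 nM to 80000 nM.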

Compound 4, concentration for 50% growth inhibition: 10000 nM
Beside the measured number, compound 4's estimate is 2.5-fold (0.40 log units) above it; the measured number falls inside the stated range.
By their numbers in this assay, from the lowest: compound 3; then compounds 2 and 4 (each within the scatter of the next); then compound 1.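

In this assay, the thiophene step reads a 10-fold higher number from compound 3 to compound 4 (1.00 log units; beyond the scatter), while the comparison with the bromo ring reads no change at the digits printed from compound 2 to compound 4 (within the scatter), so 3-methylthiophen-2-yl and 4-bromophenyl cannot be told apart on a double-bonded chain carbon bound to a double-bonded chain carbon, and among these three groups only 2-fluoro-5-nitrophenyl stands apart there. Within the data shown here, the result also gives the first measured step at a second position, on a saturated chain carbon bound to a sulfur: a 5.0-fold lower number from compound 1 to compound 4 (0.70 log units; beyond the scatter). Compound 1 and compound 4 both carry 3-methylthiophen-2-yl, and the group on that saturated chain carbon also moves this assay. No supporting evidence bears on why either step takes the size it does.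

In 2-fluoro-5-nitrophenyl the fluorine and the nitro group enter together, so their shares in the lower number of compound 3 remain unresolved; a 2-fluorophenyl, a 3-nitrophenyl or an aminophenyl group at the same place would separate them. As far as these compounds go, it also remains open whether 3,4-dichlorophenyl on the saturated chain carbon raises the number to the same extent when 2-fluoro-5-nitrophenyl occupies the double-bonded chain carbon.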